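Extending the Amino Chain of Compound 2 by One Carbon

The source may hold more compounds than are shown below. What is called first, only, known or untested is meant among the compounds shown, and "the series" means these compounds.

Of the compounds shown here, two of this set have been measured in a functional assay on PC-3 cells (Homo sapiens) for cytotoxicity, read by MTT assay, with a stated time of 48 h; on this read-out higher numbers stand for weaker inhibition and lower numbers for stronger inhibition. Compound 1 `Cc1ccc(S(=O)(=O)N2N=C(c3cc4ccccc4oc3=O)CC2c2ccccc2)cc1` gives 48600 nM. Compound 2 `CCNCC(=O)N1N=C(c2cc3ccccc3oc2=O)CC1c1ccccc1` gives 5580 nM, the lowest of the two numbers, and its nearest neighbour is compound 1. Going by the values given here, the only measured step between them, an 8.7-fold lower number from compound 1 to compound 2 (0.94 log units; beyond the scatter), puts ((ethylamino)methyl)carbonyl in place of (4-methylphenyl)sulfonyl on the amine nitrogen in the ring.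

Compound 3 `CCCNCC(=O)N1N=C(c2cc3ccccc3oc2=O)CC1c1ccccc1` is not yet measured. It differs from compound 2 by methyl in place of hydrogen on a saturated chain carbon, two bonds along the chain from an amine nitrogen; read one bond further out, the change is ethylamino to propylamino. Among the compounds with values here, no measured step bears on this part of the molecule: the single known step concerns the whole group on the ring nitrogen, not the length of the chain beyond the amine nitrogen. With nothing to suggest a shift in either direction, a step no larger than the usual scatter is expected. Compound 3 is therefore expected to give 5000 nM, within a range from 1800 nM to 14000 nM. The step this estimate implies, a 1.1-fold lower number from compound 2 to compound 3 (0.05 log units; within the scatter), is expected to stay within the scatter.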

Compound 3, half-maximal inhibitory concentration: 7270 nM
Beside the measured number, compound 3's estimate is 1.5-fold (0.16 log units) below it; the range from low to high includes it.
By their numbers in this assay, from the lowest: compounds 2 and 3 (each within the scatter of the next); then compound 1.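

In this assay, going by these compounds alone, this is the first reading on the chain beyond the amine nitrogen: ethylamino to propylamino gives a 1.3-fold higher number from compound 2 to compound 3 (0.11 log units; within the scatter), so methyl in place of hydrogen on a saturated chain carbon, two bonds along the chain from an amine nitrogen, leaves compound 3 level with compound 2 on this read-out. The lower number seen earlier on leaving (4-methylphenyl)sulfonyl also holds with the longer chain: ((propylamino)methyl)carbonyl in its place gives a 6.7-fold lower number from compound 1 to compound 3 (0.83 log units; beyond the scatter), so both amino chains stand apart from compound 1 beyond the scatter. No evidence at hand accounts for either step.

What the compounds shown leave open is how far this tolerance runs: a longer chain such as butylamino, a branched one such as isopropylamino or a ring amine such as piperidine could each read differently from ethylamino and propylamino. Also open, going by these compounds, is whether the chain would read the same with 4-chlorophenyl in place of the phenyl group on the shared core.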